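The source may hold more compounds than are shown below. What is called first, only, known or untested is meant among the compounds shown, and "the series" means these compounds.

Measured compounds in a functional assay on L02 cells (Homo sapiens) for inhibition, read by MTT assay, with a stated time of 48 h; a higher number here means a weaker inhibitor, a lower number a stronger inhibitor:
- compound 1 `COc1ccc2c(=O)c(/C=C/C(=O)NCc3ccc(F)cc3)coc2c1`; compound 1 gives > 200000 nM, a limit of this assay.
- compound 2 `COc1ccc(NC(=O)/C=C/c2coc3cc(OC)ccc3c2=O)cc1`; compound 2 gives > 200000 nM, likewise a limit.
- compound 3 `COc1ccc2c(=O)c(/C=C/C(=O)Nc3ccccc3C)coc2c1`; compound 3 gives > 200000 nM, again a limit.

Compound 3 thus stands only at a limit, as do the other two: the limit of > 200000 nM in this assay, at which 3 of the 3 values shown sit. For the measured compounds named here, the steps a step that the two limits leave unreadable from compound 1 to compound 2, a step that the two limits leave unreadable from compound 1 to compound 3 and a step that the two limits leave unreadable from compound 2 to compound 3 are all unreadable between limits, so no measured step on the amide-type nitrogen gives direction or size.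

Compound 4 `COc1ccc2c(=O)c(/C=C/C(=O)Nc3ccc(Cl)cc3)coc2c1` differs from compound 3 by 4-chlorophenyl in place of 2-methylphenyl on an amide-type nitrogen. With three variations at this position all sitting at the limit, the expected step that the limit leaves unreadable from compound 3 to compound 4 from compound 3 to compound 4 is none beyond the scatter, and compound 4 is expected to give 300000 nM, within 100000 nM to 1000000 nM, most likely again only a limit.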

Compound 4, half-maximal inhibitory concentration: > 200000 nM
Compound 4 ended at the assay's limit (the forecaster's own chance of this, stated with the estimate: 85%); the middle value does not contradict the limit.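

In this assay compound 4 gives > 200000 nM as a limit, and the steps to it from compound 1, compound 2 and compound 3 cannot be read. The compounds shown leave open whether any group on the amide-type nitrogen alters inhibition, and by how much.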